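Methylated Thiophene Swap Tested on a Second Fused Core

The source may hold more compounds than are shown below. What is called first, only, known or untested is meant among the compounds shown, and "the series" means these compounds.

Compound 1 `N=C(N)N/N=C/c1c(-c2ccsc2)nc2sccn12` and compound 2 `Cc1cc(-c2nc3sccn3c2/C=N/NC(=N)N)c(C)s1` share one core, while compound 3 `N=C(N)N/N=C/c1c(-c2ccsc2)nc2n1CCS2` and the not yet measured compound 4 `Cc1cc(-c2nc3n(c2/C=N/NC(=N)N)CCS3)c(C)s1` share another; the difference between the two cores is not broken down here. In a functional assay on cells (Melanoma cell, Homo sapiens) for inhibition (a higher number here means a weaker inhibitor of growth, a lower number a stronger inhibitor of growth), compound 1 gives 17000 nM, compound 2 gives 16200 nM, and compound 3 gives 21900 nM, so all three numbers lie within the scatter of one another.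

Among the compounds with values here, the change 2,5-dimethylthiophen-3-yl in place of thiophen-3-yl on an aromatic carbon produced a 1.0-fold lower number from compound 1 to compound 2 (0.02 log units; within the scatter), that is, essentially no step. The same kind of change is now made on the second core: 2,5-dimethylthiophen-3-yl in place of thiophen-3-yl on an aromatic carbon. The surroundings are not identical, since in compound 4 the carbon carrying the change is also two ring bonds from two ring atoms that each bear a fused ring, which is not the case in compound 2.

Because a 1.0-fold lower number from compound 1 to compound 2 (0.02 log units; within the scatter) stayed within the scatter, compound 4 is expected to give about 21000 nM in this assay. Compound 4 is estimated to fall between 10000 nM and 45000 nM, which means an expected step of a 1.0-fold lower number from compound 3 to compound 4 (0.02 log units; within the scatter).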

Compound 4, concentration for 50% growth inhibition: 15500 nM
Compound 4: the middle estimate sits 1.4-fold (0.13 log units) above what was measured; low and high end bracket the measured number.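

In this assay, placing 2,5-dimethylthiophen-3-yl where thiophen-3-yl stood on the second core gives a 1.4-fold lower number from compound 3 to compound 4 (0.15 log units; within the scatter). Set beside the same change on the first core, this step shows no difference that can be told from noise: the same change on two cores in this assay, a 1.0-fold lower number (0.02 log units; within the scatter) from compound 1 to compound 2 and a 1.4-fold lower number (0.15 log units; within the scatter) from compound 3 to compound 4, 1.3-fold (0.13 log units) apart, within the scatter of two such steps

So the two added methyl groups leave the number within the scatter on both cores, but this does not show that the two cores respond alike to every change, as a pair of steps this small offers little to compare and says nothing about changes that do move the number.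

From the compounds shown here alone, it remains open whether another group on the same aromatic carbon, such as a phenyl ring, an amine or a carboxylic acid, would shift growth inhibition beyond the scatter on either core. If one did, the compounds shown could not say whether the step would be the same size on both cores.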